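Sulfonamide Nitrogen Replaced by a Plain Phenyl Sulfone

The source may hold more compounds than are shown below. What is called first, only, known or untested is meant among the compounds shown, and "the series" means these compounds.

compound 1, `CC1(C)C=C(n2ccccc2=O)c2cc(S(N)(=O)=O)ccc2O1`: 77.5%
compound 2, `CC1(C)C=C(n2ccccc2=O)c2cc(S(=O)(=O)Nc3ccccc3)ccc2O1`: 63.6%; 82.5% (2 entries)
compound 3, `CC1(C)C=C(n2ccccc2=O)c2cc(S(=O)(=O)Nc3ccc([N+](=O)[O-])cc3)ccc2O1`: 82.2%

In a functional assay on the whole organism (aorta) with Rattus norvegicus as the target (on this read-out higher numbers stand for larger maximal responses and lower numbers for smaller maximal responses), compound 3 and compound 1 lie within the scatter of each other, as the step of a number 4.7 percentage points higher from compound 1 to compound 3 (within the scatter) shows, and the two entries of compound 2 spread on both sides of them (the several entries of compound 2 in this assay, 63.6%; 82.5% (2 entries)). Compound 4, `CC1(C)C=C(n2ccccc2=O)c2cc(S(=O)(=O)c3ccccc3)ccc2O1`, differs from compound 3 by phenyl in place of (4-nitrophenyl)amino on a sulfonyl sulfur. Going by the values given here, no measured step alters the sulfonyl sulfur in this way; the one measured step, a number 4.7 percentage points higher from compound 1 to compound 3 (within the scatter), stays within the scatter, and the repeats in the several entries of compound 2 in this assay, 63.6%; 82.5% (2 entries) show how widely single numbers can fall. So no shift beyond the scatter is expected, with an estimated step of a number 6.2 percentage points lower from compound 3 to compound 4 (within the scatter). Compound 4 is therefore expected to reach 76%, estimated between 58% and 92%.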

Compound 4, largest response reached (Emax), in percent of the reference or control that the assay uses: 79.3%
Compound 4: middle estimate off by 3.3 percentage points, on the low side; the range from low to high includes it.
By their numbers in this assay, from the lowest: compounds 1, 4 and 3 (each within the scatter of the next).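

With phenyl on the sulfonyl sulfur, the group no longer has a nitrogen or a hydrogen-bond donor, yet the steps stay small: a number 2.9 percentage points lower from compound 3 to compound 4 (within the scatter) and a number 1.8 percentage points higher from compound 1 to compound 4 (within the scatter). In this assay, the sulfonamide nitrogen is therefore not required for a large maximal response in this series. Small differences deserve caution, as repeat measurements can differ widely: the several entries of compound 2 in this assay, 63.6%; 82.5% (2 entries)

Still open, on these data alone, is whether a methyl group on the sulfonyl sulfur, or a carboxylic acid on the phenyl ring, would also preserve the response in this assay.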